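Adding Chloro to the Anilino Ring of Compound 2

The compounds below may be only part of what the source reports. "The series", "measured", "known", "first", "only" and "open" are said of these compounds alone.

Three compounds have been measured in a functional assay on the whole organism (strain Wister albino) for inhibition, with Rattus norvegicus as the target, read by paw edema, with stated times of 1 h and 4 h, at a dose of 50 mg/kg by the intraperitoneal route; on this read-out lower numbers stand for less inhibition and higher numbers for more inhibition at the one dose given (going by the name of the read-out):

Compound 1, `CCOC(=O)c1c(-c2ccc(Cl)c(Cl)c2)cc(-c2ccccc2)nc1N1CCCCC1`: 95.1%
Compound 2, `CCOC(=O)c1c(-c2ccc(Cl)cc2)cc(-c2ccccc2)nc1Nc1ccccc1`: 123%
Compound 3, `CCOC(=O)c1c(-c2ccc(Cl)c(Cl)c2)cc(-c2ccccc2)nc1Nc1ccc(C)cc1`: 87.9%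

Compound 2 stands highest of the three, with compound 1 lower by a gap beyond the scatter and compound 3 lower still. The next compound, compound 4, `CCOC(=O)c1c(-c2ccc(Cl)cc2)cc(-c2ccccc2)nc1Nc1ccc(Cl)cc1`, differs from compound 2 by chloro in place of hydrogen on an aromatic carbon. For the measured compounds named here, only one measured step is a change in a single place: a number 7.2 percentage points lower from compound 1 to compound 3 (within the scatter), which replaces the whole amine group and lies within the scatter. Going by the values given here, it is not the same kind of change as adding chloro, so no measured step bears directly on the move from compound 2 to compound 4. Compound 2 and compound 3 differ in two places, so their values alone tell nothing about chloro on the anilino ring. Among the compounds with values here, with no guiding step, compound 4 is expected to stay close to compound 2, at about 115%, between 90% and 135%. The expected step is a number 8 percentage points lower from compound 2 to compound 4 (within the scatter), not beyond the scatter.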

Compound 4, a percentage reported as inhibition, in the whole organism at one dose (the size of the read-out at that dose, not a potency): 95.9%
Compound 4: the middle estimate sits 19.1 percentage points above what was measured, and the stated range covers the measured number.
By their numbers in this assay, from the lowest: compounds 3, 1 and 4 (each within the scatter of the next); then compound 2.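

For the compounds shown here, putting chloro in place of hydrogen on the anilino ring, para to a large group, gives a number 27.1 percentage points lower from compound 2 to compound 4 (beyond the scatter) in this assay, and this is the only measured step that changes that ring alone. The earlier step swapped a whole amine group and stayed within the scatter, whereas here a single added heavy atom moves the number beyond it, so this place on the ring does affect the read-out. Nothing measured here explains why the number falls with this change.

The compounds shown leave open whether another group at the same place, such as methoxy, a carboxylic acid or an amine, would lower the number as much as chloro does. They also leave open whether chloro at other places on the anilino ring, or the same change on a different core, would give a similar step.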